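Oxygen to sulfur at the aryl linker of the core

The source may report more compounds than this note shows. Statements on the series, on what has been measured and on what is new or still open speak of the compounds shown alone.

Compound 3 `Nc1cc(N)c2nc(-c3ccccc3)c(Oc3ccc(F)cc3)nc2c1` is the only one of the three measured compounds with a number in a functional assay on 786-0 cells (Homo sapiens) for inhibition, read by sulforhodamine B assay, with a stated time of 48 h; on this read-out higher numbers stand for lower toxicity in this test and lower numbers for higher toxicity in this test: compound 3 gives 75900 nM. Compound 1 `Nc1cc(N)c2nc(-c3ccccc3)c(NCc3ccc(F)cc3)nc2c1` carries a (4-fluorobenzyl)amino group on the same aromatic carbon, and in this assay compound 1 returns only a limit of the assay, < 100000 nM. Compound 2 `Nc1cc(N)c2nc(-c3ccccc3)c(Sc3ccc(Cl)c(Cl)c3)nc2c1` bears a (3,4-dichlorophenyl)sulfanyl group there, and in this assay compound 2 likewise returns only a limit, < 100000 nM. The steps a step that the two limits leave unreadable from compound 1 to compound 2, a step that the limit leaves unreadable from compound 1 to compound 3 and a step that the limit leaves unreadable from compound 2 to compound 3 thus have no readable size; all that the two limit compounds show is the limit of < 100000 nM in this assay, at which 2 of the 3 values shown sit.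

Compound 4 `Nc1cc(N)c2nc(-c3ccccc3)c(Sc3ccc(F)cc3)nc2c1`, not yet measured, differs from compound 3 by (4-fluorophenyl)sulfanyl in place of 4-fluorophenoxy on an aromatic carbon. Within the data shown here, no measured step exchanges only the linking atom, so none bears directly on this change, and the steps that exist are unreadable. With compound 3 sitting just under the limit at which compounds 1 and 2 stand, no step beyond the scatter is expected, and a 1.2-fold lower number from compound 3 to compound 4 (0.07 log units; within the scatter) is the step the estimate means. Compound 4 is estimated at 65000 nM in this assay, with an expected range from 25000 nM to 100000 nM, and a real chance that only a limit is reported.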

Compound 4, concentration lethal to 50% of the cells: < 100000 nM
Compound 4 was reported as a limit (the forecaster's own chance of this, stated with the estimate: 35%); the middle value lies beyond the limit too.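

Compound 4 returns only a limit in this assay, so its steps to compound 1, compound 2 and compound 3 cannot be read, and no new step follows: the limit of < 100000 nM in this assay, at which 3 of the 4 values shown sit.

On these data alone, whether exchanging 4-fluorophenoxy for (4-fluorophenyl)sulfanyl changes the number at all remains open, as does how far compound 1, compound 2 and compound 4 lie from compound 3.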